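Lengthening the alkyl chain on the enone of compound 1

This account rests on a few compounds, and the source may have more. Where it says the series, first, only, none or still open, it means among the compounds named here.

Measured compounds:
compound 1, `C=C(CC)C(=O)c1ccc(OC(C)C(=O)OC)c(C)c1C`, 4600 nM
compound 2, `C=C(C)C(=O)c1ccc(OC(C)C(=O)O)cc1C`, > 60000 nM
compound 3, `C=C(CC)C(=O)c1ccc(OCC(=O)OC)c(Cl)c1Cl`, 3900 nM

In a functional assay on HL-60 cells (Homo sapiens) for antiproliferative activity, with a stated time of 72 h (on this read-out higher numbers stand for weaker inhibition of growth and lower numbers for stronger inhibition of growth), compound 1 gives 4600 nM, the higher of the two numbers recorded, though compound 3 with 3900 nM lies within the scatter of it, so the two are not distinguishable. For compound 2 this assay reports only a limit, > 60000 nM, as noted by the limit of > 60000 nM in this assay, at which 1 of the 3 values shown sits.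

Compound 4 is `C=C(CCCC)C(=O)c1ccc(OC(C)C(=O)OC)c(C)c1C`. It differs from compound 1 by ethyl in place of hydrogen on a saturated chain carbon, two bonds along the chain from a double-bonded chain carbon. No pair of measured compounds shows the effect of such a chain extension, and no reason for a direction is in hand. A small change is expected, a 1.3-fold lower number from compound 1 to compound 4 (0.12 log units; within the scatter), not clearly beyond the scatter. Compound 4 is therefore estimated at 3500 nM, in the range 1200 nM to 10000 nM.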

Compound 4, concentration for 50% growth inhibition: 5200 nM
Beside the measured number, compound 4's estimate is 1.5-fold (0.17 log units) below it, and the stated range covers the measured number.
By their numbers in this assay, from the lowest: compounds 3, 1 and 4 (each within the scatter of the next). At a limit, above all of these: compound 2.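

In this assay, among the compounds shown here, compounds 1 and 4 form the first pair to isolate a change at this position, and replacing ethyl with butyl gives a 1.1-fold higher number from compound 1 to compound 4 (0.05 log units; within the scatter). This position therefore accepts the longer chain with no difference that can be told from the scatter, at least on the core of compound 1. No available evidence bears on this result.

As far as these compounds go, it remains open whether a longer chain, a phenyl ring or an amine at this position would also leave the number within the scatter. From the compounds shown here alone, it is equally open whether the same extension would read alike on compound 3 .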